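This account rests on a few compounds, and the source may have more. Where it says the series, first, only, none or still open, it means among the compounds named here.

Measured compounds:
- Compound 1 `COc1ccc(/C=C/[C@@](C)(/C=C/c2ccc(O)c(C=O)c2)CCC=C(C)C)cc1`: 2270 nM
- Compound 2 `CCOC(=O)/C(C)=C/c1cc(/C=C/[C@](C)(/C=C/c2ccc(OC)cc2)CCC=C(C)C)ccc1O`: > 36600 nM (a limit)
- Compound 3 `COc1ccc(/C=C/[C@@](C)(/C=C/c2ccc(O)c(/C=C/C(=O)OC(C)(C)C)c2)CCC=C(C)C)cc1`: > 36600 nM (a limit)

In an ADME assay on HEK293 cells (Homo sapiens) for cytotoxicity, with a stated time of 72 h (a lower number here means that less compound is needed, a higher number that more compound is needed for the effect), compound 3 stands at the limit of > 36600 nM in this assay, at which 2 of the 3 values shown sit. Its reading is a limit of the assay, not a number. Only compound 1 gives a true number. Replacing its formyl group produced two large steps, an at least 16-fold higher number from compound 1 to compound 2 (1.20 log units; beyond the scatter) and an at least 16-fold higher number from compound 1 to compound 3 (1.20 log units; beyond the scatter). The step closest to the present change is a step that the two limits leave unreadable from compound 2 to compound 3, and it cannot be sized.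

Compound 4 `COc1ccc(/C=C/[C@@](C)(/C=C/c2ccc(O)c(/C=C/C(=O)OCc3ccccc3)c2)CCC=C(C)C)cc1` keeps the chain of compound 3 but alters its end: benzyl in place of tert-butyl on an oxygen next to a carbonyl group. It thus carries 2-(benzyloxycarbonyl)ethenyl where compound 1 has formyl. Among the measured compounds shown here, no measured step isolates this swap, so the expectation rests on the large steps away from compound 1, an at least 16-fold higher number from compound 1 to compound 3 (1.20 log units; beyond the scatter) above all. The new chain resembles those of compounds 2 and 3, so no step beyond the scatter is expected, in either direction, and a reading at the limit is likely. The expected change is an at least 1.0-fold lower number from compound 3 to compound 4 (0.00 log units; that floor lies within the scatter). The estimate for compound 4 is 36000 nM, with an expected range of 12000 nM to 60000 nM.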

Compound 4, half-maximal effective concentration: > 36600 nM
Compound 4 gave a limit, no number; the forecaster's own chance of this, stated with the estimate: 70%; middle value at least 1.0-fold (0.00 log units) away from the limit.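

In this assay compound 4 gives > 36600 nM, which is a limit of the assay and not a number. With benzyl, which brings a six-membered aromatic ring onto the oxygen next to the carbonyl group, the ester chain at this position still differs sharply from the formyl group, with an at least 16-fold higher number from compound 1 to compound 4 (1.20 log units; beyond the scatter). The steps among compound 2, compound 3 and compound 4 cannot be read, and the three ester compounds now share one reading: the limit of > 36600 nM in this assay, at which 3 of the 4 values shown sit.

The ester compounds give no true number, so any difference between tert-butyl and benzyl at this end of the chain stays hidden. On these data alone, it also remains open whether the ester itself or the longer chain separates these compounds from compound 1, a question that a carboxylic acid or an amine on the same ethenyl chain could help to address.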